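Liver microsome half-life: from compound 3 to compound 4

The compounds below may be only part of what the source reports. "The series", "measured", "known", "first", "only" and "open" are said of these compounds alone.

Among the measured compounds shown here, compound 3 `CC(C)C(Nc1nccs1)c1ccc(-c2ccc3cccc(F)c3c2)[nH]c1=O` holds the lowest half-life of the three measured members: in an ADME assay on microsomes from liver (Homo sapiens) for metabolic stability (on this read-out lower numbers stand for a shorter-lived compound and higher numbers for a longer-lived compound), compound 3 gives 0.17 h. Compound 1 `CC(C)C(c1nnc[nH]1)c1ccc(-c2ccc3cccc(F)c3c2)[nH]c1=O` gives 0.905 h in this assay, and compound 2 `CC(C)NC(=O)CC(c1ccc(-c2ccc3cccc(F)c3c2)[nH]c1=O)C(C)C` gives 0.32 h. The measured steps are a 5.3-fold lower number from compound 1 to compound 3 (0.73 log units; beyond the scatter), a 2.8-fold lower number from compound 1 to compound 2 (0.45 log units; beyond the scatter) and a 1.9-fold lower number from compound 2 to compound 3 (0.27 log units; within the scatter).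

Compound 4 `CC(C)C(c1ccc(-c2ccc3cccc(F)c3c2)[nH]c1=O)N1CCNC1=O` differs from compound 3 at the same place: 2-oxoimidazolidin-1-yl in place of (1,3-thiazol-2-yl)amino on a saturated chain carbon bound to an aromatic carbon and a saturated chain carbon.

The steps from compound 1 bear on this change: exchanging the 4H-1,2,4-triazol-3-yl for either of the other groups on the saturated chain carbon lowered the half-life, so compound 3 is the member from which a return upward is most plausible. For the measured compounds named here, the entering 2-oxoimidazolidin-1-yl is neither the triazole nor the thiazolylamine, and no step measures it directly. A modest rise is expected, a 1.9-fold higher number from compound 3 to compound 4 (0.27 log units; within the scatter), which may not clear the scatter.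

Compound 4 is therefore estimated at 0.32 h in this assay, with a range from 0.13 h to 0.8 h.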

Compound 4, half-life: 1.03 h
Beside the measured number, compound 4's estimate is 3.2-fold (0.51 log units) below it; measured number outside the range, above it.
By their numbers in this assay, from the lowest: compounds 3 and 2 (each within the scatter of the next); then compounds 1 and 4 (each within the scatter of the next).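

Notes on the saturated chain carbon bound to an aromatic carbon and a saturated chain carbon, read in this assay: a long half-life here is not confined to the aromatic 4H-1,2,4-triazol-3-yl, since the non-aromatic 2-oxoimidazolidin-1-yl matches it within the scatter (a 1.1-fold higher number from compound 1 to compound 4 (0.06 log units; within the scatter)). The same group also stands clear of both lower compounds (a 3.2-fold higher number from compound 2 to compound 4 (0.51 log units; beyond the scatter); a 6.1-fold higher number from compound 3 to compound 4 (0.78 log units; beyond the scatter)), and the step from the (1,3-thiazol-2-yl)amino group comes with no change in heavy atom count, showing that this place responds strongly to groups of equal size. No measurement at hand accounts for these steps.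

Going by these compounds, whether the ring itself matters remains open, as an open-chain urea at this place would test. Also open, on these data alone, is how a methyl group on the ring nitrogen carrying the amide hydrogen of the 2-oxoimidazolidin-1-yl would read.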